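Working notes on a steryl-sulfatase inhibitor series

The source may hold more compounds than are shown below. What is called first, only, known or untested is meant among the compounds shown, and "the series" means these compounds.

Measured so far:
compound 1, `CCN(Cc1ccc(Br)cc1)c1cccc(C(=O)N2CCc3ccc(OS(N)(=O)=O)cc3C2)c1`: 24.2%
compound 2, `CCN(Cc1ccncc1)c1ccc(C(=O)N2CCc3ccc(OS(N)(=O)=O)cc3C2)cc1`: 47%

Both were tested in an assay on HEK293 cells for inhibition of Steryl-sulfatase (Homo sapiens), tested at 0.1 uM; a higher number here means a stronger effect of the compound at the concentration tested, a lower number a weaker effect. Compound 1 gives 24.2%, the lowest of the two numbers in hand; compound 2 gives 47%, a number higher by a gap that lies beyond the scatter. Among the measured compounds shown here, no pair of measured compounds differs in only one place, so no single change has a measured size, and the higher value of compound 2 cannot be tied to any one part of its structure.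

Compound 3, `CCCN(CCC)c1cccc(C(=O)N2CCc3ccc(OS(N)(=O)=O)cc3C2)c1`, has not been measured. Against compound 1 the difference is dipropylamino in place of (4-bromobenzyl)(ethyl)amino on an aromatic carbon. The six-membered aromatic ring of carbon only and the bromine are gone; what remains on that aromatic carbon, meta to a large group, is a chain-only substituent with no ring.

For the measured compounds named here, with no measured step to anchor the size of this change, the expected step is a number 2.8 percentage points higher from compound 1 to compound 3 (within the scatter), not beyond the scatter in either direction. Compound 3 is therefore estimated at 27%, with a range from 8% to 50%.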

Compound 3, a percentage reported as inhibition, at one concentration (the size of the read-out at that concentration, not a potency): 8.3%
Beside the measured number, compound 3's estimate is 18.7 percentage points above it; the range from low to high includes it.
By their numbers in this assay, from the lowest: compound 3; then compound 1; then compound 2.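

In this assay, dipropylamino in place of (4-bromobenzyl)(ethyl)amino on an aromatic carbon gives the series its first step of measured size, a number 15.9 percentage points lower from compound 1 to compound 3 (beyond the scatter), which shows that the read-out responds to the group at this position, meta to a large group. The group with no ring, which has fewer heavy atoms, does not keep the number of compound 1, even though the two groups have the same hydrogen-bond donor and acceptor counts. Nothing in hand bears on why the number falls with this change.

This single step removes the six-membered aromatic ring, the bromine and the ethyl chain together, so it leaves open which of these parts accounts for the difference; a plain benzyl group or a cyclohexylmethyl group in place of the 4-bromobenzyl, with the ethyl kept, would each test one part of it. From the compounds shown here alone, whether a diethylamino group or a longer chain such as dibutylamino at this position would track chain length also remains open, as does the size of any single change leading to compound 2, which differs from compound 1 and compound 3 in more than one place.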